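A few compounds are considered here, and "the series" means these few. Any claim that something is new, unique, unknown or untested is made for them only; others in the source may bear on it.

Compound 1, `C#CCN(C)CCCCOc1ccc2c(c1)CCC2=O`, is the shortest of the series, and in an assay on BTI cells for inhibition of Amine oxidase [flavin-containing] B (Homo sapiens), read by fluorescence and Amplex Red, with a stated time of 15 min (on this read-out higher numbers stand for weaker inhibition and lower numbers for stronger inhibition), compound 1 gives 366 nM. Compound 2, `C#CCN(C)CCCCCCOc1ccc2c(c1)CCC2=O`, differs from it in one place: 2-(methyl(propargyl)amino)ethyl in place of methyl(propargyl)amino on a saturated chain carbon, four bonds along the chain from an oxygen on an aromatic ring. That change produced a 2.8-fold lower number from compound 1 to compound 2 (0.45 log units; beyond the scatter), so in this assay compound 2 gives 129 nM. Compound 3, `C#CCN(C)CCCCCCOc1ccc2c(c1)OCCC2=O`, carries a different core; how the core of compound 3 differs from the core of compound 1 is not broken down here. In this assay compound 3 gives 117 nM, the lowest number among the three measured compounds, though its gap to compound 2 lies within the scatter, so no order between compound 2 and compound 3 can be claimed, and only its gap to compound 1 lies beyond the scatter.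

Compound 4, `C#CCN(C)CCCCCCCCOc1ccc2c(c1)OCCC2=O`, has not yet been measured. It differs from compound 3 in one place: 2-(methyl(propargyl)amino)ethyl in place of methyl(propargyl)amino on a saturated chain carbon, six bonds along the chain from an oxygen on an aromatic ring. This is the same kind of change as that from compound 1 to compound 2, but not the same: the earlier one sat four bonds along the chain from an oxygen on an aromatic ring, whereas this one sits six bonds along the chain from an oxygen on an aromatic ring, and the core is that of compound 3 rather than of compound 1. Going by the values given here, the expectation rests on the one measured instance, namely a 2.8-fold lower number from compound 1 to compound 2 (0.45 log units; beyond the scatter), but because compound 3 already gives 117 nM on the longer chain, a smaller step is expected this time, a 1.6-fold lower number from compound 3 to compound 4 (0.19 log units; within the scatter). For compound 4 in this assay a value of 75 nM is estimated, expected to fall between 35 nM and 200 nM.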

Compound 4, half-maximal inhibitory concentration: 422 nM
Compound 4: middle estimate off by 5.6-fold (0.75 log units), on the low side; measured number above the stated range.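

On the core of compound 3, placing 2-(methyl(propargyl)amino)ethyl in place of methyl(propargyl)amino, six bonds along the chain from an oxygen on an aromatic ring, gave a 3.6-fold higher number from compound 3 to compound 4 (0.56 log units; beyond the scatter) in this assay, and the two instances of this change do not agree: the same change on two cores in this assay, a 2.8-fold lower number (0.45 log units; beyond the scatter) from compound 1 to compound 2 and a 3.6-fold higher number (0.56 log units; beyond the scatter) from compound 3 to compound 4, 10-fold (1.01 log units) apart, beyond the scatter of two such steps

This shows that neither the size nor the direction of the change can be carried from one compound pair to another in this series, as the number fell in the first pair and rose in the second. It does not show whether the core or the place on the chain decides the outcome: the earlier change sat four bonds along the chain on the core of compound 1, the later one six bonds along on the core of compound 3, and these two pairs cannot separate the two differences.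

The compounds shown leave open how the chain of compound 4 behaves on the core of compound 1, and how the chain of compound 1 behaves on the core of compound 3. They also leave open what a longer chain than that of compound 4 would give, or a dimethylamine in place of the methyl(propargyl)amino group.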